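A longer side group on compound 2

The source may hold more compounds than are shown below. What is called first, only, known or untested is meant among the compounds shown, and "the series" means these compounds.

Measured so far in a functional assay on HT-29 cells (Homo sapiens) for inhibition, read by MTT assay, with a stated time of 3 days (on this read-out lower numbers stand for stronger inhibition and higher numbers for weaker inhibition), are two compounds.

- Compound 1 `C/C=C/COc1cc(/C=C\c2cc(OC)c(OC)c(OC)c2)ccc1OC` gives 161000 nM
- Compound 2 `COc1ccc(COc2cc(/C=C\c3cc(OC)c(OC)c(OC)c3)ccc2OC)cc1` gives 47000 nM

Compound 2 at 47000 nM holds the lower of the two numbers, and here a lower number means stronger inhibition. The next compound, compound 3 `COc1ccc(/C=C/CCCOc2cc(/C=C\c3cc(OC)c(OC)c(OC)c3)ccc2OC)cc1`, keeps the shared core and changes one group. The change is 4-(4-methoxyphenyl)but-3-en-1-yl in place of 4-methoxyphenyl on a saturated chain carbon bound to an oxygen on an aromatic ring and the entering group still carries a six-membered aromatic ring of carbon only, now with a double bond outside aromatic rings.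

Within the data shown here, only one measured step bears on this change. It is a 3.4-fold lower number from compound 1 to compound 2 (0.53 log units; beyond the scatter) and it is modest but beyond the scatter. It came with 4-methoxyphenyl taking the place of prop-1-en-1-yl. Compound 3 keeps that 4-methoxyphenyl within its larger group, so a return to the higher number of compound 1 is not expected. Among the measured compounds shown here, no measured compound shows what the longer chain does, so the evidence is thin.

The expected change is a 1.2-fold lower number from compound 2 to compound 3 (0.07 log units; within the scatter) in this assay and it is expected to be small, with a wide margin in either direction. For compound 3 the estimated value is 40000 nM with an expected range from 14000 nM to 120000 nM in this assay.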

Compound 3, half-maximal inhibitory concentration: 47000 nM
Beside the measured number, compound 3's estimate is 1.2-fold (0.07 log units) below it; the range from low to high includes it.
By their numbers in this assay, from the lowest: compounds 2 and 3 (each within the scatter of the next); then compound 1.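

In this assay, the larger 4-(4-methoxyphenyl)but-3-en-1-yl in place of 4-methoxyphenyl, on a saturated chain carbon bound to an oxygen on an aromatic ring, gives no change at the digits printed from compound 2 to compound 3 (within the scatter), so this position accepts the longer group with its added double bond without a measurable change in the read-out. The advantage over the small prop-1-en-1-yl group also remains, with a 3.4-fold lower number from compound 1 to compound 3 (0.53 log units; beyond the scatter), which means that both compounds carrying the methoxy-bearing aromatic ring now lie on the same side of compound 1. No independent measurement here explains why the number holds steady when the group grows.

The compounds shown leave open whether the aromatic ring itself goes with the lower number, a question that a plain hexyl chain at this place could address. They also leave open whether the double bond in the chain matters, which the fully saturated 4-(4-methoxyphenyl)butyl group could test, and how a chain ending in an amine or a carboxylic acid would behave.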